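This account rests on a few compounds, and the source may have more. Where it says the series, first, only, none or still open, it means among the compounds named here.

Compound 1 `O=C[C@H](C[C@@H]1CCNC1=O)NC(=O)[C@H](CC1CC1)NC(=O)OCc1ccccc1` gives in an ADME assay on Vero C1008 cells (Chlorocebus sabaeus) for cytotoxicity, read by luminescence and CellTiter-Glo, with a stated time of 24 h (on this read-out higher numbers stand for lower toxicity in this test and lower numbers for higher toxicity in this test), a value that is a limit of the assay, > 200000 nM.
Compound 2 `O=C[C@H](C[C@@H]1CCNC1=O)NC(=O)[C@H](CC1CC1)NC(=O)OCCc1cccc(Cl)c1` gives in this assay a limit, > 200000 nM.
Compound 3 `C[C@H](OC(=O)N[C@@H](CC1CC1)C(=O)N[C@H](C=O)C[C@@H]1CCNC1=O)c1ccccc1` gives in this assay a limit, > 200000 nM.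

Compound 1 therefore stands only at a limit, and the two further values shown are limits as well, as the limit of > 200000 nM in this assay, at which 3 of the 3 values shown sit, records. The steps a step that the two limits leave unreadable from compound 1 to compound 2, a step that the two limits leave unreadable from compound 1 to compound 3 and a step that the two limits leave unreadable from compound 2 to compound 3 are all unreadable for the same reason and give no measured size to carry over.

Compound 4 `O=C(N[C@@H](CC1CC1)C(=O)N[C@@H](C[C@@H]1CCNC1=O)C(O)S(=O)(=O)O)OCc1ccccc1` differs from compound 1 in one place: hydroxy(sulfo)methyl in place of formyl on a saturated chain carbon bound to an amide-type nitrogen and a saturated chain carbon. Going by the values given here, none of the measured steps touches this position, so no step of readable size bears on it; the expectation rests on the limits alone. Compound 4 is expected to remain at or beyond the limit, a step that the limit leaves unreadable from compound 1 to compound 4, with an estimated value of 300000 nM in the range 120000 nM to 800000 nM.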

Compound 4, half-maximal cytotoxic concentration: > 200000 nM
Compound 4 ended at the assay's limit; the forecaster's own chance of this, stated with the estimate: 85%; the middle value is on the limit's open side.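

No step can be read from compound 1 to compound 4, because both values are limits: the limit of > 200000 nM in this assay, at which 4 of the 4 values shown sit. The compounds shown leave open at what concentration, if any, each of them would turn cytotoxic in this assay.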